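The source may hold more compounds than are shown below. What is called first, only, known or untested is meant among the compounds shown, and "the series" means these compounds.

Measured so far:
Compound 1 `CCc1nc(N)c2nc(O)n(Cc3ccccc3)c2n1`: 1 uM
Compound 2 `COc1nc2c(N)ncnc2n1Cc1ccccc1`: > 10 uM

In a functional assay (spleen, spleen) for activation, with Mus musculus as the target (on this read-out lower numbers stand for an effect already at smaller amounts and higher numbers for an effect only at larger amounts of compound), compound 1 gives 1 uM, and this is the only plain number among the measurements shown. Compound 2 gives no number in this assay, only a limit, > 10 uM; this is the limit of > 10 uM in this assay, at which 1 of the 2 values shown sits. Going by the values given here, compound 1 therefore stands alone with a measured value, and no step between two measured compounds can be drawn from these data.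

Compound 3 `Nc1nc(S)nc2c1nc(O)n2Cc1ccccc1` has not yet been measured in this assay. It differs from compound 1 in one place: sulfanyl in place of ethyl on an aromatic carbon.

Among the compounds with values here, with no measured step to lean on, the expectation for compound 3 rests only on the fact that compound 1 gives a number while compound 2 gives a limit, and on the size of the change. The replacement is expected to move this assay toward higher numbers, and the step of a 5.0-fold higher number from compound 1 to compound 3 (0.70 log units; beyond the scatter) is estimated to lie beyond the usual scatter. Compound 3 is expected to come out near 5 uM, within a range from 1 uM to 30 uM.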

Compound 3, minimum effective concentration: 10 uM
Compound 3: the middle estimate sits 2.0-fold (0.30 log units) below what was measured; measured number inside the range.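

Going by these compounds alone, the change from ethyl to sulfanyl on the aromatic carbon between two ring nitrogen atoms gives the first measured step in this assay, a 10-fold higher number from compound 1 to compound 3 (1.00 log units; beyond the scatter), so this position is not indifferent to the group it carries. The change does not remove the read-out, since compound 3 still gives a plain number, 10 uM, in this assay. Compound 2 differs from both in more than one place and gives only a limit, not a number, so it adds no step to this comparison: the limit of > 10 uM in this assay, at which 1 of the 3 values shown sits.

With a single step at this position, the compounds shown leave open whether the higher number goes with the loss of ethyl or with the arrival of sulfanyl, as the two happen together in this one exchange. A methyl group, a longer chain such as propyl or an amine on the same carbon would help to separate these two readings and show whether the number in this assay follows the size of the group or its kind.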